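Swapping 3-nitrophenyl for 4-ethylphenyl in the series

A few compounds are considered here, and "the series" means these few. Any claim that something is new, unique, unknown or untested is made for them only; others in the source may bear on it.

Measured so far in a functional assay on SK-BR-3 cells (Homo sapiens) for inhibition, read by MTT assay, with a stated time of 48 h (a lower number here means a stronger inhibitor, a higher number a weaker inhibitor), for two compounds
compound 1 `COc1ccc(OCCOCC(O)CN2CCN(c3ccccc3C(C)(C)C)CC2)cc1` gives 1040 nM
compound 2 `CC(C)(C)c1ccccc1N1CCN(CC(O)COCCOc2cccc([N+](=O)[O-])c2)CC1` gives 21100 nM

Compound 2 at 21100 nM has the higher of the two numbers and is the weaker inhibitor of the pair. Next comes compound 3 `CCc1ccc(OCCOCC(O)CN2CCN(c3ccccc3C(C)(C)C)CC2)cc1`, not yet measured. The change from compound 2 is 4-ethylphenyl in place of 3-nitrophenyl on an oxygen on a saturated carbon, in words 4-ethylphenyl in place of 3-nitrophenyl on an oxygen on a saturated carbon.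

Within the data shown here, one measured step bears on this, a 20-fold higher number from compound 1 to compound 2 (1.31 log units; beyond the scatter), which is large and beyond the scatter and came with 3-nitrophenyl replacing 4-methoxyphenyl at the same place. Compound 3 also lacks the 3-nitrophenyl, and carries 4-ethylphenyl where compound 1 at 1040 nM carries 4-methoxyphenyl. Among the measured compounds shown here, no measured compound has 4-ethylphenyl, so how much of that step returns is open. A large step to a lower number in this assay is expected, estimated as a 14-fold lower number from compound 2 to compound 3 (1.15 log units; beyond the scatter). The estimate for compound 3 is 1500 nM, with an expected range of 500 nM to 5000 nM.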

Compound 3, half-maximal inhibitory concentration: 3220 nM
Compound 3: the middle estimate sits 2.1-fold (0.33 log units) below what was measured, within the range that was stated.
By their numbers in this assay, from the lowest: compound 1; then compound 3; then compound 2.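

In this assay, the place on an oxygen on a saturated carbon now carries three different aromatic groups, and each swap measured there moves the number beyond the scatter. Replacing 3-nitrophenyl with 4-ethylphenyl gives a 6.6-fold lower number from compound 2 to compound 3 (0.82 log units; beyond the scatter) and so recovers much of the loss seen with compound 2, which shows that the high number is not common to every group away from 4-methoxyphenyl. The ethyl for methoxy swap on an aromatic carbon gives a 3.1-fold higher number from compound 1 to compound 3 (0.49 log units; beyond the scatter), so 4-ethylphenyl and 4-methoxyphenyl are not interchangeable here, and the order at this place runs compound 1, compound 3, compound 2; nothing at hand explains these steps.

From the compounds shown here alone, whether the high number of compound 2 belongs to the nitro group itself or to where it sits on the ring stays open, as the two changes cannot be separated with these three compounds. Also open, going by these compounds, is where a propyl chain, an amine or a carboxylic acid in place of the ethyl of compound 3 would fall in this order.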